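This account rests on a few compounds, and the source may have more. Where it says the series, first, only, none or still open, it means among the compounds named here.

Measured in a functional assay on HCT-116 cells (Homo sapiens) for inhibition, read by sulforhodamine B assay, with a stated time of 48 h; a lower number here means a stronger inhibitor of growth, a higher number a weaker inhibitor of growth:
Compound 2, `CC(=O)/C(=C\c1c(-c2ccccc2)[nH]c2ccccc12)S(=O)(=O)c1ccccc1`: 754 nM
Compound 1, `COc1ccc2[nH]c(-c3ccccc3)c(C=C(C#N)C#N)c2c1`: 4400 nM

Compound 2 has the lowest of the two numbers in this assay. Its nearest neighbour is compound 1, whose number is higher by a margin that lies beyond the scatter of repeated measurements, so compound 2 stands as the stronger inhibitor of growth of the two. The two compounds differ in more than one place, and no single step between them is shown, so only their two values are compared here.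

Compound 3, `N#C/C(=C\c1c(-c2ccccc2)[nH]c2ccccc12)S(=O)(=O)c1ccccc1`, has not yet been measured. It differs from compound 2 in one place: cyano in place of acetyl on a double-bonded chain carbon bound to a double-bonded chain carbon and a sulfonyl sulfur. Among the compounds with values here, no measured pair shows this change, so its effect has to be estimated from the two numbers at hand. In this assay a step of modest size is expected, most likely toward a somewhat higher number, though a step of no more than the scatter is also plausible. For compound 3 the expected value is 1100 nM, within a range from 300 nM to 3500 nM, a step of a 1.5-fold higher number from compound 2 to compound 3 (0.16 log units; within the scatter).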

Compound 3, concentration for 50% growth inhibition: 2000 nM
Estimate against measurement, compound 3: 1.8-fold (0.26 log units) below; the range from low to high includes it.
By their numbers in this assay, from the lowest: compound 2; then compound 3; then compound 1.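

In this assay the acetyl group on this double-bonded chain carbon, bound to a double-bonded chain carbon and a sulfonyl sulfur, cannot be exchanged for cyano without a loss: the change gives a 2.7-fold higher number from compound 2 to compound 3 (0.42 log units; beyond the scatter) and this modest step lies beyond the scatter. Within the data shown here, this is the only single change that can be read among the compounds, and it shows that the number at this position responds to the group placed there, with acetyl holding the lower number of the two groups tried on an otherwise unchanged structure. The data offer no measurement that accounts for the difference between acetyl and cyano at this place.

The compounds shown leave open whether a methyl ester, a primary amide or a longer acyl chain at this place would bring the number below that of acetyl or push it higher still. They also leave open whether the step from acetyl to cyano would keep its size with a different group in place of the phenylsulfonyl group, or on the core of compound 1.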